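A few compounds are considered here, and "the series" means these few. Any claim that something is new, unique, unknown or untested is made for them only; others in the source may bear on it.

Working notes on the series, read in a functional assay on MCF7 cells (Homo sapiens) for inhibition, read by MTT assay, with a stated time of 72 h; a higher number here means a weaker inhibitor, a lower number a stronger inhibitor. Compound 1 `CC(C)C(=O)N1CCN(c2nnc3nncn3n2)CC1` gives 1810 nM, and compound 2 `CCC(=O)N1CCN(c2nnc3nncn3n2)CC1` gives 14800 nM. Compound 3 `OCC(CO)(CO)Nc1nnc2nncn2n1` gives > 100000 nM, which is a limit of the assay and not a number. Compound 2 therefore holds the higher of the two actual numbers, with compound 1 as its nearest neighbour.

Next is compound 4 `CCCCC(=O)N1CCN(c2nnc3nncn3n2)CC1`, which differs from compound 2 by ethyl in place of hydrogen on a saturated chain carbon, two bonds along the chain from a carbonyl carbon, turning propanoyl into butylcarbonyl. Among the measured compounds shown here, only one measured step bears on this change: an 8.2-fold higher number from compound 1 to compound 2 (0.91 log units; beyond the scatter), with hydrogen in place of methyl. That step suggests that added carbon on this side of the carbonyl may lower the number. The support is thin, as it is a single step, and ethyl enters here rather than methyl, at a different place. The expected change is a 3.3-fold lower number from compound 2 to compound 4 (0.52 log units; beyond the scatter), estimated to run toward a lower number and to be smaller than the measured step. For compound 4 the estimate is 4500 nM, with an expected range of 1200 nM to 16000 nM.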

Compound 4, half-maximal inhibitory concentration: 2760 nM
For compound 4 the middle estimate is 1.6-fold (0.21 log units) above the measured one; measured number inside the range.
By their numbers in this assay, from the lowest: compounds 1 and 4 (each within the scatter of the next); then compound 2. At a limit, above all of these: compound 3.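

In this assay, the change from propanoyl to butylcarbonyl moves the number clearly (a 5.4-fold lower number from compound 2 to compound 4 (0.73 log units; beyond the scatter)), with ethyl in place of hydrogen on a saturated chain carbon, two bonds along the chain from a carbonyl carbon. The earlier step covered only methyl in place of hydrogen, on the carbon bound to the carbonyl carbon; two different additions of carbon to the propanoyl group of compound 2 now give a lower number. Branching does not separate the two better compounds (butyl in place of isopropyl on a carbonyl carbon, a 1.5-fold higher number from compound 1 to compound 4 (0.18 log units; within the scatter)), so the straight chain and the branched chain cannot be ranked here.

The compounds shown leave open whether a longer chain, or an amine or a carboxylic acid at the end of the chain, would keep or change this number. Nothing measured here gives a reason for either step.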